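Swapping the sulfonyl aryl group: what compound 4 should show

This account rests on a few compounds, and the source may have more. Where it says the series, first, only, none or still open, it means among the compounds named here.

Measured compounds:
Compound 1, `CC[C@H](C)[C@H](NC(=O)c1cccc(Cn2ccnc2)c1)C(=O)NS(=O)(=O)c1ccccc1`, gives 18000 nM in an assay on HEK293 cells for displacement of a labelled ligand from Type-2 angiotensin II receptor (Homo sapiens); a higher number here means a weaker inhibitor, a lower number a stronger inhibitor.
Compound 2, `CC[C@H](C)[C@H](NC(=O)c1cccc(Cn2ccnc2)c1)C(=O)NNS(=O)(=O)c1c(C)cc(C)cc1C`, gives 8500 nM in this assay.
Compound 3, `CC[C@H](C)[C@H](NC(=O)c1cccc(Cn2ccnc2)c1)C(=O)NNS(=O)(=O)c1ccc(OC)cc1`, gives 9200 nM in this assay.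

Compound 2 has the lowest number of the three in this assay; compound 3 lies within the scatter of it, while compound 1 lies beyond the scatter. Compound 4, `CC[C@H](C)[C@H](NC(=O)c1cccc(Cn2ccnc2)c1)C(=O)NNS(=O)(=O)c1ccc(C)cc1`, differs from compound 2 in one place: 4-methylphenyl in place of 2,4,6-trimethylphenyl on a sulfonyl sulfur. Among the compounds with values here, the only measured step that bears on this change is the one that also exchanges the aryl group on the sulfonyl sulfur, a 1.1-fold higher number from compound 2 to compound 3 (0.03 log units; within the scatter). That step stayed within the scatter, so the expected step of a 1.1-fold higher number from compound 2 to compound 4 (0.02 log units; within the scatter) is likewise no change beyond the scatter. Compound 4 is therefore estimated at 9000 nM in this assay, with a range from 4000 nM to 20000 nM.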

Compound 4, inhibition constant: 29000 nM
For compound 4 the middle estimate is 3.2-fold (0.51 log units) below the measured one; the measured number lies above the stated range.
By their numbers in this assay, from the lowest: compounds 2, 3, 1 and 4 (each within the scatter of the next, the first and the last beyond it).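

In this assay the aryl group on the sulfonyl sulfur turns out to matter, which the earlier swap did not show: 4-methylphenyl in place of 2,4,6-trimethylphenyl raises the number (a 3.4-fold higher number from compound 2 to compound 4 (0.53 log units; beyond the scatter)), and methyl in place of methoxy on an aromatic carbon does so to a similar size (a 3.2-fold higher number from compound 3 to compound 4 (0.50 log units; beyond the scatter)). The change on the amide-type nitrogen, by contrast, stays within the scatter (a 1.6-fold higher number from compound 1 to compound 4 (0.21 log units; within the scatter)). As far as these compounds go, whether an amine or a carboxylic acid in place of that methyl would lower or raise the number remains open. No measurement shown accounts for these steps.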